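Tail variation on a para-substituted phenylxanthine series

The source may report more compounds than this note shows. Statements on the series, on what has been measured and on what is new or still open speak of the compounds shown alone.

Measured so far:
compound 1 `CCCn1c(=O)c2nc(-c3ccc(OCC(=O)NCCN=C(S)Nc4ccc(OC)cc4)cc3)[nH]c2n(CCC)c1=O` — 33.2 nM
compound 2 `CCCn1c(=O)c2nc(-c3ccc(OCC(=O)NCCNS(=O)(=O)c4cccc(S(=O)(=O)Cl)c4)cc3)[nH]c2n(CCC)c1=O` — 2.5 nM
compound 3 `CCCn1c(=O)c2nc(-c3ccc(OCC(=O)NCCNC(=O)C/N=C(\S)Nc4ccc(N=C=S)cc4)cc3)[nH]c2n(CCC)c1=O` — 6.85 nM

All three share the same core and differ only in the group carried at the end of the aminoethyl chain. In an assay on brain for binding affinity to adenosine receptor A1 (Rattus norvegicus), read by radioligand binding (a higher number here means a weaker inhibitor, a lower number a stronger inhibitor), compound 1 gives 33.2 nM, the highest number of the three. Compound 3 sits at 6.85 nM, a gap beyond the scatter, and compound 2 at 2.5 nM, further still. Both of the two compounds with lower numbers than compound 1 carry a tail built around an acylated or sulfonylated nitrogen rather than the thiourea of compound 1, but with three compounds and three different tails no pattern can be claimed.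

Compound 4 `CCCn1c(=O)c2nc(-c3ccc(OCC(=O)NCCNC(=O)c4ccc(CBr)cc4)cc3)[nH]c2n(CCC)c1=O` is not yet measured. It differs from compound 1 by a group of 11 heavy atoms (8 carbon, 1 nitrogen, 1 oxygen, 1 bromine; one six-membered aromatic ring of carbon only) in place of a group of 12 heavy atoms (8 carbon, 2 nitrogen, 1 oxygen, 1 sulfur; one six-membered aromatic ring of carbon only), on a saturated chain carbon, two bonds along the chain from an amide-type nitrogen. Within the data shown here, no two measured compounds differ in one place only, so no measured step guides this change. The expectation is a step in this assay from compound 1 to compound 4 of a 2.8-fold lower number from compound 1 to compound 4 (0.44 log units; beyond the scatter), toward a lower number, on the basis that compound 2 at 2.5 nM and compound 3 at 6.85 nM both lie well below compound 1. Compound 4 is estimated at 12 nM, with a range from 3 nM to 45 nM.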

Compound 4, inhibition constant: 11.5 nM
Beside the measured number, compound 4's estimate is 1.0-fold (0.02 log units) above it; measured number inside the range.
By their numbers in this assay, from the lowest: compound 2; then compounds 3 and 4 (each within the scatter of the next); then compound 1.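

In this assay, among these compounds, this position now has its first comparison in which only one place changes: a 2.9-fold lower number from compound 1 to compound 4 (0.46 log units; beyond the scatter) accompanies the entry of ((4-(bromomethyl)phenyl)carbonyl)amino. The step is modest, yet it shows that one tail carrying a six-membered aromatic ring of carbon only can replace another at this saturated chain carbon with the number going down rather than up. No measurement on hand speaks to what lies behind this step.

On these data alone, it remains open whether the bromomethyl group itself contributes to the lower number, or whether a methyl or an aminomethyl group in its place would read the same. Also open, as far as these compounds go, is how a longer chain between the amide-type nitrogen and the benzoyl ring would read in this assay.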